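This account rests on a few compounds, and the source may have more. Where it says the series, first, only, none or still open, it means among the compounds named here.

Measured compounds:
compound 1, `Cc1ccc(NC2=CC(=O)c3nc4n(c3C2=O)[C@H]2OC[C@@H](O)[C@H]2OC4)cc1`, 3860 nM
compound 2, `O=C1C(Nc2cccc(Cl)c2)=CC(=O)c2c1nc1n2[C@H]2OC[C@@H](O)[C@H]2OC1`, 7970 nM

In a functional assay on HeLa cells (Homo sapiens) for inhibition, read by sulforhodamine B assay (on this read-out lower numbers stand for stronger inhibition and higher numbers for weaker inhibition), compound 1 gives the lowest of the two numbers recorded; compound 2 gives a number that is higher by an amount beyond the usual scatter, so the two values are distinguishable. Within the data shown here, no direct step between the measured pair is set out, so only the two values themselves can be compared.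

Compound 3, `O=C1C=C(Nc2ccc(Br)cc2)C(=O)c2c1nc1n2[C@H]2OC[C@@H](O)[C@H]2OC1`, has not yet been measured in this assay. It differs from compound 1 in one place: bromo in place of methyl on an aromatic carbon. The change keeps the count of heavy atoms, ring membership, donors, acceptors and charge unchanged and sits on an aromatic carbon of a six-membered aromatic ring of carbon only.

Among the measured compounds shown here, no measured step of this kind is available, so the size of the step is uncertain. Compound 3 is expected to give a number close to that of compound 1, with a step of a 1.0-fold higher number from compound 1 to compound 3 (0.02 log units; within the scatter), that is, none beyond the scatter. The estimate for compound 3 in this assay is 4000 nM, within a range from 1500 nM to 11000 nM.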

Compound 3, half-maximal inhibitory concentration: 3830 nM
The estimate for compound 3 lay 1.0-fold (0.02 log units) above the measured number; the range from low to high includes it.
By their numbers in this assay, from the lowest: compounds 3 and 1 (each within the scatter of the next); then compound 2.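

Among these compounds, the pair gives the only step in which a single place changes. In this assay, placing bromo instead of methyl on the aromatic carbon para to a large group gives a 1.0-fold lower number from compound 1 to compound 3 (0.00 log units; within the scatter), so the two compounds cannot be told apart. At this position, then, 4-methylphenyl and 4-bromophenyl read alike on the shared core, which the separate values of the earlier compounds could not show, and no measured property of these groups is available to explain the match. From the compounds shown here alone, what remains open is whether this insensitivity extends to other groups at the same position, such as an amine, a carboxylic acid or a longer chain such as butyl. The compounds shown also include no single-place step that tests bromo or methyl on a different aromatic carbon of the ring.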